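A few compounds are considered here, and "the series" means these few. Any claim that something is new, unique, unknown or untested is made for them only; others in the source may bear on it.

Measured in a functional assay on L1210 cells (Mus musculus) for inhibition; a lower number here means a stronger inhibitor, a higher number a weaker inhibitor:
- Compound 1 `Nc1nc(O)c2ncn(C/C=C/CO)c2n1`: 200000 nM
- Compound 2 `Nc1ccn(C/C=C/CCl)c(=O)n1`: 50000 nM

Compound 2 has the lower of these two numbers, which makes it the stronger inhibitor of the pair, and its gap to compound 1 lies beyond the usual scatter of repeated measurements. Even so, both numbers are large, and two compounds are a very small basis for any trend.

Compound 3 `Nc1ccn(C/C=C\CCl)c(=O)n1` has not yet been measured in this assay. Its relation to compound 2 is as close as two structures can be: the two compounds have the same atoms and bonds and differ only in configuration as drawn: 1 of 1 stereo elements differ; a double bond is drawn E in compound 2 and Z in compound 3. Nothing else changes, so a double bond drawn E in compound 2 is drawn Z in compound 3.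

Going by the values given here, no measured pair here isolates a change of this kind, so the data offer no direction for it. Among the compounds with values here, the only anchor is compound 2 at 50000 nM. The expected result is therefore no change beyond the scatter, with no change at the digits printed from compound 2 to compound 3 (within the scatter) as the estimated step. Compound 3 is estimated at 50000 nM, within an expected range of 15000 nM to 170000 nM.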

Compound 3, half-maximal inhibitory concentration: 10000 nM
Compound 3: middle estimate off by 5.0-fold (0.70 log units), on the high side, and the stated range ends above it.
By their numbers in this assay, from the lowest: compound 3; then compound 2; then compound 1.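

In this assay, changing the double bond from drawn E to drawn Z gives a 5.0-fold lower number from compound 2 to compound 3 (0.70 log units; beyond the scatter), the first measured effect of a single change in this set. The shift can be assigned to the geometry of this one bond, because no atom or bond is added or removed: the fact that compounds 2 and 3 differ only in the configuration as drawn. The chlorine-bearing chain therefore does not act the same in its two shapes, although compound 3 at 10000 nM still has a large number, and this finding rests on a single pair.

Whether the Z geometry would bring a similar change on the core of compound 1 remains open, as does the reason the shape of the chain matters in these cells. It is also unknown whether the preference for Z would hold with an amine or a fluorine in place of the chlorine, or with a longer chain.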